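The source may hold more compounds than are shown below. What is called first, only, known or untested is meant among the compounds shown, and "the series" means these compounds.

Compound 3 `CCCC(=O)c1ccc(OCCCCOc2cc(C(=O)O)ccc2OC)c(C)c1O` gives the lowest of the two numbers recorded in an assay on HEK293 cells for positive allosteric modulation of metabotropic glutamate receptor 2 (Rattus norvegicus), read by thallium flux, with a stated time of 2.5 min (a higher number here means that more compound is needed for the effect, a lower number that less compound is needed), at 103 nM; compound 2 `CCC(=O)c1ccc(OCCCCOc2cc(C(=O)O)ccc2OC)c(C)c1O` gives 162 nM in this assay, and for compound 1 `COC(=O)c1ccc(OCCCCOc2ccc(C(=O)CC3CCCC3)c(C)c2C)cc1` the entry in this assay reads "not determined" (no result reported). The change to compound 4 `COc1ccc(C(=O)O)cc1OCCCCOc1ccc(C(=O)C(C)C)c(O)c1C` is isopropyl in place of propyl on a carbonyl carbon. Among the measured compounds shown here, the one measured step that bears on the same part of the molecule is a 1.6-fold lower number from compound 2 to compound 3 (0.20 log units; within the scatter), and it lay within the scatter. Because that step, a 1.6-fold lower number from compound 2 to compound 3 (0.20 log units; within the scatter), changed little, compound 4 is expected to land close to compound 3, with a step of a 1.0-fold lower number from compound 3 to compound 4 (0.01 log units; within the scatter) rather than anything beyond the scatter. Compound 4 is therefore estimated at 100 nM in this assay, with a range from 40 nM to 250 nM.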

Compound 4, half-maximal effective concentration: 116 nM
Beside the measured number, compound 4's estimate is 1.2-fold (0.06 log units) below it; low and high end bracket the measured number.
By their numbers in this assay, from the lowest: compounds 3, 4 and 2 (each within the scatter of the next).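

In this assay, isopropyl in place of propyl on a carbonyl carbon gives a 1.1-fold higher number from compound 3 to compound 4 (0.05 log units; within the scatter), and methyl in place of hydrogen on the chain carbon bound to that carbonyl carbon gives a 1.4-fold lower number from compound 2 to compound 4 (0.15 log units; within the scatter). Both steps lie within the scatter, so among compounds 2, 3 and 4, branching this chain has now been seen to be tolerated as well as extending it. No measurement shown explains this result.
The compounds leave open whether a longer chain or an amine on this carbonyl carbon would still stay within the scatter.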